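Swapping a Hexyl Chain for Cyclohexylmethyl

The source may report more compounds than this note shows. Statements on the series, on what has been measured and on what is new or still open speak of the compounds shown alone.

Measured so far in an ADME assay on a cell-free system (plasma, Homo sapiens) for metabolic stability, read by LC-MS (a lower number here means that the compound disappears faster, a higher number that the compound lasts longer), for three compounds
Compound 1 `NCc1ccc(C(=O)Nc2ccncc2F)cc1-c1cccc(C(=O)Oc2ccccc2)c1` (0.117 h)
Compound 2 `CCCCOC(=O)c1cccc(-c2cc(C(=O)Nc3ccncc3)ccc2CN)c1` (0.367 h)
Compound 3 `CCCCCCOC(=O)c1cccc(-c2cc(C(=O)Nc3ccncc3)ccc2CN)c1` (0.833 h)

Compound 3 stands highest of the three in this assay and its gaps to compound 2 and compound 1 both lie beyond the scatter. The next compound to be measured is compound 4 `NCc1ccc(C(=O)Nc2ccncc2)cc1-c1cccc(C(=O)OCC2CCCCC2)c1`. It keeps the shared core and has cyclohexyl in place of pentyl on a saturated chain carbon bound to an oxygen next to a carbonyl group. Put another way, hexyl gives way to cyclohexylmethyl.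

Within the data shown here, only one measured step bears on this. Lengthening the chain gave a 2.3-fold higher number from compound 2 to compound 3 (0.36 log units; beyond the scatter) and was modest. That step adds no ring, and compound 1 differs from compound 3 in more than one place, so the direction remains uncertain. A slight rise at most is expected, and the estimated step is a 1.2-fold higher number from compound 3 to compound 4 (0.08 log units; within the scatter) in size. The estimate for compound 4 is 1 h (expected range 0.4 h to 2.5 h).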

Compound 4, half-life: 1.65 h
Estimate against measurement, compound 4: 1.7-fold (0.22 log units) below; the measured number falls inside the stated range.
By their numbers in this assay, from the lowest: compound 1; then compound 2; then compounds 3 and 4 (each within the scatter of the next).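

In this assay, cyclohexyl in place of pentyl gives a 2.0-fold higher number from compound 3 to compound 4 (0.30 log units; within the scatter) and so, on this saturated chain carbon, a ring cannot be told apart from the open hexyl chain. Cyclohexyl in place of propyl gives a 4.5-fold higher number from compound 2 to compound 4 (0.65 log units; beyond the scatter) and this shows that the gain over the butyl chain does not require an open chain, as compound 3 alone could not show. Nothing at hand explains why these numbers fall as they do.

The compounds shown leave open whether an octyl chain would carry the numbers further or whether the ring itself could be varied, as with a cyclopentylmethyl or benzyl group. They also leave open how an amine or a carboxylic acid at the end of the chain would fare at this place.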